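Replacing the imidazolyl of compound 3 with phenethyl

The source may hold more compounds than are shown below. What is called first, only, known or untested is meant among the compounds shown, and "the series" means these compounds.

In an assay on CHO cells for antagonist activity at transient receptor potential cation channel subfamily V member 1 (Homo sapiens), read by FLIPR (on this read-out lower numbers stand for stronger inhibition and higher numbers for weaker inhibition), compound 1 `CC(C(=O)NCc1ccc(C(F)(F)F)nc1-c1ccc(F)c(Cl)c1)c1ccc(NS(C)(=O)=O)c(F)c1` gives 0.2 nM, compound 2 `CC(C(=O)NCc1ccc(C(F)(F)F)nc1-c1ccoc1)c1ccc(NS(C)(=O)=O)c(F)c1` gives 1.4 nM, and compound 3 `CC(C(=O)NCc1ccc(C(F)(F)F)nc1-n1ccnc1)c1ccc(NS(C)(=O)=O)c(F)c1` gives 36.1 nM. Compound 3 stands highest of the three numbers: a 180-fold higher number from compound 1 to compound 3 (2.26 log units; beyond the scatter) and a 26-fold higher number from compound 2 to compound 3 (1.41 log units; beyond the scatter), both beyond the scatter, while the exchange of the carbon-only ring for the furan, a 7.0-fold higher number from compound 1 to compound 2 (0.85 log units; beyond the scatter), is the smaller move.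

Compound 4 `CC(C(=O)NCc1ccc(C(F)(F)F)nc1CCc1ccccc1)c1ccc(NS(C)(=O)=O)c(F)c1` differs from compound 3 in one place: phenethyl in place of 1H-imidazol-1-yl on an aromatic carbon. The two steps into compound 3 are the ones that bear on this, and both are large. Compound 4 carries a six-membered ring of carbon only, as compound 1 does, though here on a two-carbon chain rather than joined directly to the shared core, so a full return to the number of compound 1 is not assumed.

The expected step is a 14-fold lower number from compound 3 to compound 4 (1.16 log units; beyond the scatter), a large move toward lower numbers. Compound 4 is estimated at 2.5 nM, with a range of 0.4 nM to 15 nM.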

Compound 4, inhibition constant: 1.4 nM
Compound 4: middle estimate off by 1.8-fold (0.25 log units), on the high side; measured number inside the range.
By their numbers in this assay, from the lowest: compound 1; then compounds 2 and 4 (each within the scatter of the next); then compound 3.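

In this assay the high number of compound 3 does not hold for every group at this place: the step is a 26-fold lower number from compound 3 to compound 4 (1.41 log units; beyond the scatter) and a ring of carbon only, carried on a chain, serves here as well as a directly attached furan-3-yl, with no change at the digits printed from compound 2 to compound 4 (within the scatter) as the comparison. The remaining step, a 7.0-fold higher number from compound 1 to compound 4 (0.85 log units; beyond the scatter) on the same read-out, combines a change of link with the loss of chlorine and fluorine, so it cannot be assigned to either alone. No measurement given here accounts for these steps.

From the compounds shown here alone, it remains open whether the imidazolyl number follows from its ring nitrogens or from its attachment through nitrogen. Unsubstituted phenyl, benzyl and 3-phenylpropyl at this place would separate ring substitution from chain length.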